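From methyl to butyl on a shared core

A few compounds are considered here, and "the series" means these few. Any claim that something is new, unique, unknown or untested is made for them only; others in the source may bear on it.

Measured compounds:
- compound 1, `CC(C)(C)c1ccc(/C(=C/C(=O)Nc2ccc3c(c2)OCCO3)CCC(=O)O)cc1`: in a functional assay on CHO cells for inhibition of transient receptor potential cation channel subfamily V member 1 (Homo sapiens) (on this read-out higher numbers stand for weaker inhibition and lower numbers for stronger inhibition), compound 1 reaches only the limit > 4000 nM.
- compound 2, `O=C(/C=C/c1ccccc1)Nc1ccc2c(c1)OCCO2`: in this assay compound 2 reaches only the limit > 4000 nM.
- compound 3, `Cc1ccc(/C=C/C(=O)Nc2ccc3c(c2)OCCO3)cc1`: in this assay compound 3 gives 1100 nM.

Compound 3 holds the only number shown; the other two values are limits, and the limit of > 4000 nM in this assay, at which 2 of the 3 values shown sit, marks where those two sit. Among the measured compounds shown here, the one measured step that bears on the question is an at least 3.6-fold lower number from compound 2 to compound 3 (0.56 log units; beyond the scatter), which shows that putting a small alkyl group onto the aromatic ring of the shared core moves the read-out from a limit to a measurable number.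

Compound 4, `CCCCc1ccc(/C=C/C(=O)Nc2ccc3c(c2)OCCO3)cc1`, carries the change (propyl in place of hydrogen on a saturated chain carbon bound to an aromatic carbon). Read one bond further out, the same difference is methyl to butyl, so the alkyl chain that already helped in the step from compound 2 to compound 3 is simply made longer.

For the measured compounds named here, with only that one step to lean on, the expectation for compound 4 is a step of modest size toward a lower number, though a change within the scatter is also plausible. The estimated step is a 2.2-fold lower number from compound 3 to compound 4 (0.34 log units; beyond the scatter). For compound 4 in this assay the expected value is 500 nM, with a likely range from 150 nM to 3000 nM.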

Compound 4, half-maximal inhibitory concentration: 2700 nM
For compound 4 the middle estimate is 5.4-fold (0.73 log units) below the measured one; the range from low to high includes it.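

Making the alkyl group longer, from methyl to butyl, does not extend the gain that methyl brought: in this assay the change gives a 2.5-fold higher number from compound 3 to compound 4 (0.39 log units; beyond the scatter). Butyl set against plain hydrogen on the aromatic carbon gives an at least 1.4-fold lower number from compound 2 to compound 4 (0.17 log units; that floor lies within the scatter), so a real gain from butyl over hydrogen is not established, unlike the step for methyl, which is an at least 3.6-fold lower number from compound 2 to compound 3 (0.56 log units; beyond the scatter). The value of compound 2 is a limit and not a number, so the comparison of butyl with hydrogen has only a floor and no exact size: the limit of > 4000 nM in this assay, at which 2 of the 4 values shown sit.

From the compounds shown here alone, with only methyl and butyl as measured chains, it remains open whether ethyl or propyl in the same place would read closer to compound 3 or to compound 4. The compounds shown also do not tell why the longer chain gives the higher number, or how an amine or a hydroxyl group on the butyl chain would read.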